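Ester in Place of Methoxy(methyl)amide on the Shared Core

The compounds below may be only part of what the source reports. "The series", "measured", "known", "first", "only" and "open" are said of these compounds alone.

Compound 1 `CCOC(=O)C[C@H]1[C@@H](O[Si](C)(C)C(C)(C)C)[C@H](n2cnc3c(NC(=O)Nc4ccccc4)ncnc32)O[C@@H]1COC(=O)NC`: 11.7 nM in a functional assay on HCT-15 cells (Homo sapiens) for antiproliferative activity; a lower number here means a stronger inhibitor of growth, a higher number a weaker inhibitor of growth
Compound 2 `CNC(=O)NC[C@H]1O[C@@H](n2cnc3c(NC(=O)Nc4ccccc4)ncnc32)[C@H](O[Si](C)(C)C(C)(C)C)[C@@H]1CC(=O)N(C)OC`: 6.47 nM in this assay

Compound 2 gives the lower of the two numbers, yet compound 1 sits within the scatter of it, so no order between the two is claimed. Compound 3 `CCOC(=O)C[C@H]1[C@@H](O[Si](C)(C)C(C)(C)C)[C@H](n2cnc3c(NC(=O)Nc4ccccc4)ncnc32)O[C@@H]1CNC(=O)NC` differs from compound 2 by a single change: ethoxy in place of methoxy(methyl)amino on a carbonyl carbon. For the measured compounds named here, no pair of measured compounds that differ in one place is available to gauge this change directly. Compound 1 also carries the ethoxycarbonyl group and gives 11.7 nM in this assay, so the step of a 1.4-fold higher number from compound 2 to compound 3 (0.14 log units; within the scatter) is expected to stay within the scatter. For compound 3 the expected value is 9 nM, ranging from 3 nM to 30 nM.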

Compound 3, concentration for 50% growth inhibition: 8.5 nM
Compound 3: middle estimate off by 1.1-fold (0.02 log units), on the high side; the measured number falls inside the stated range.
By their numbers in this assay, from the lowest: compounds 2, 3 and 1 (each within the scatter of the next).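

In this assay, ethoxy in place of methoxy(methyl)amino on a carbonyl carbon can now be read directly: a 1.3-fold higher number from compound 2 to compound 3 (0.12 log units; within the scatter) leaves the two groups indistinguishable at this position. The shared core also gives a second direct reading, as a 1.4-fold lower number from compound 1 to compound 3 (0.14 log units; within the scatter) accompanies (methylcarbamoyl)amino in place of (methylcarbamoyl)oxy on a saturated chain carbon bound to a saturated ring carbon, so these two groups cannot be told apart either. No supporting measurement bears on either step. Going by these compounds, whether a carboxylic acid or a longer chain ester on that carbonyl carbon would also stay within the scatter remains open.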